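This account rests on a few compounds, and the source may have more. Where it says the series, first, only, none or still open, it means among the compounds named here.

All numbers here come from an ADME assay on MDCK cells (Canis lupus familiaris) for cytotoxicity; a higher number here means that more compound is tolerated, a lower number that less compound is tolerated.

Measured so far:
compound 1, `O=[N+]([O-])C1=NNc2nc(C(F)(F)F)nn2C1c1ccc(O)cc1O`, 108000 nM
compound 2, `O=[N+]([O-])C1=NNc2ncnn2C1c1ccc(O)cc1O`, 90000 nM
compound 3, `O=[N+]([O-])C1=CNc2ncnn2C1c1ccc(O)c(O)c1O`, 405000 nM

Compound 1 and compound 2 share one core and differ only where compound 1 carries trifluoromethyl in place of hydrogen on an aromatic carbon. The step between them, a 1.2-fold higher number from compound 2 to compound 1 (0.08 log units; within the scatter), is small, so the two values are not told apart in this assay. Compound 3 sits on a different core; the difference between the core of compound 2 and the core of compound 3 is not broken down here. In this assay compound 3 gives the highest number of the three, with both other compounds clearly lower, compound 1 nearer to it and compound 2 furthest from it.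

Compound 4, `O=[N+]([O-])C1=CNc2nc(C(F)(F)F)nn2C1c1ccc(O)c(O)c1O`, has not yet been measured. It stands to compound 3 as compound 1 stands to compound 2: it carries trifluoromethyl in place of hydrogen on an aromatic carbon, at a place described in the same words as for compound 1, so this is the same change, now made on the core of compound 3.

Among the measured compounds shown here, for this assay the expectation is a step of about the size seen before, a 1.2-fold higher number from compound 3 to compound 4 (0.07 log units; within the scatter), resting on the fact that the same change gave a 1.2-fold higher number from compound 2 to compound 1 (0.08 log units; within the scatter) in the only measured pair. Compound 4 is accordingly estimated at 480000 nM, expected to fall between 200000 nM and 1100000 nM. Whether this holds on the second core is exactly what the pending measurement of compound 4 will show.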

Compound 4, half-maximal cytotoxic concentration: 373000 nM
The estimate for compound 4 lay 1.3-fold (0.11 log units) above the measured number, and the stated range covers the measured number.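

In this assay, among the compounds shown here, trifluoromethyl in place of hydrogen on an aromatic carbon gives a 1.1-fold lower number from compound 3 to compound 4 (0.04 log units; within the scatter), so on the core of compound 3 the change again produces no step that can be told from the scatter. Set beside the earlier pair, the change reads the same on both cores, and no dependence on the core can be seen: the same change on two cores in this assay, a 1.2-fold higher number (0.08 log units; within the scatter) from compound 2 to compound 1 and a 1.1-fold lower number (0.04 log units; within the scatter) from compound 3 to compound 4, 1.3-fold (0.11 log units) apart, within the scatter of two such steps

This supports carrying the change between these two cores without expecting a detectable shift in this assay, but it rests on just two pairs and does not show that the same would hold on any further core, nor does it explain why the number stays put or separate what the cores themselves contribute.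

The compounds shown leave open whether a different group on this aromatic carbon, between two ring nitrogen atoms, such as an amine, a carboxylic acid or a longer chain, would also leave the number in this assay unresolved from that of the hydrogen compound. Also open, going by these compounds, is whether the same quiet behaviour would survive replacing the nitro group with a nitrile, or removing one of the hydroxyl groups, since each pair here varies only at the one carbon.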